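The source may hold more compounds than are shown below. What is called first, only, known or untested is meant among the compounds shown, and "the series" means these compounds.

Two compounds built on one shared core have so far been examined in an ADME assay on NIH3T3 cells (Mus musculus) for cytotoxicity, read by XTT assay, with a stated time of 24 h; on this read-out higher numbers stand for weaker inhibition and lower numbers for stronger inhibition. Compound 1 `Fc1ccc(C2CC(c3ccc(Cl)s3)=NN2c2nc(-c3ccc(Br)cc3)cs2)cc1` gives > 500 ug/mL, a value that is a limit of the assay and not a number. Compound 2 `Cc1ccc(C2=NN(c3nc(-c4ccc(S(C)(=O)=O)cc4)cs3)C(c3ccc(F)cc3)C2)s1` differs from compound 1 in more than one place. In this assay compound 2 gives 374 ug/mL. Where compound 1 stands is therefore known only through (the limit of > 500 ug/mL in this assay, at which 1 of the 2 values shown sits), and no pair of measured compounds differing in a single place is available to show how large a change in this series moves the read-out.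

Compound 3 `Fc1ccc(-c2csc(N3N=C(c4ccc(Cl)s4)CC3c3ccc(F)cc3)n2)cc1` has not yet been measured. It differs from compound 1 by fluoro in place of bromo on an aromatic carbon, the place being an aromatic carbon of a six-membered aromatic ring of carbon only, para to a large group. The expected step, an at least 1.1-fold lower number from compound 1 to compound 3 (0.04 log units; that floor lies within the scatter), is small and within the usual scatter of this assay, in no particular direction. For compound 3 the estimated value is 450 ug/mL, with a range from 200 ug/mL to 1000 ug/mL, and a real chance that the assay again returns only a limit.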

Compound 3, half-maximal inhibitory concentration: > 500 ug/mL
Compound 3 was reported as a limit (the forecaster's own chance of this, stated with the estimate: 55%); middle value at least 1.1-fold (0.04 log units) away from the limit.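

In this assay, compound 3, like compound 1, returns only a limit of the assay and not a number, so no step can be read between these two compounds: the limit of > 500 ug/mL in this assay, at which 2 of the 3 values shown sit.

From the compounds shown here alone, whether the change from 4-bromophenyl to 4-fluorophenyl moves the read-out at all, and by how much, remains open.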